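This account rests on a few compounds, and the source may have more. Where it says the series, first, only, none or still open, it means among the compounds named here.

Measured in a functional assay on HeLa cells (Homo sapiens) for inhibition, read by CCK-8 assay, with a stated time of 48 h; a higher number here means a weaker inhibitor, a lower number a stronger inhibitor:

- Compound 1 `COc1cc(-c2ccnc3cc(-c4ccc5c(ccn5C)c4)nn23)cc(OC)c1OC`: 19 nM
- Compound 2 `COc1cc(-c2ccnc3cc(-c4ccc(C(C)=O)cc4)nn23)cc(OC)c1OC`: 1810 nM
- Compound 3 `COc1ccc(-c2cc3nccc(-c4cc(OC)c(OC)c(OC)c4)n3n2)cc1`: 373 nM

Compound 3 has the second highest of these three numbers, with compound 2 above it and compound 1 below it. Going on to compound 4 `COc1cc(-c2ccnc3cc(-c4ccc5cnn(C)c5c4)nn23)cc(OC)c1OC`, the structural change is 1-methyl-1H-indazol-6-yl in place of 4-methoxyphenyl on an aromatic carbon. The 4-methoxyphenyl leaves, and a 1-methyl-1H-indazol-6-yl takes its place on an aromatic carbon.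

The closest guide is a 20-fold higher number from compound 1 to compound 3 (1.29 log units; beyond the scatter), a large step in which 4-methoxyphenyl replaces 1-methyl-1H-indol-5-yl. The same place also gave a 95-fold higher number from compound 1 to compound 2 (1.98 log units; beyond the scatter), which is large, and a 4.9-fold lower number from compound 2 to compound 3 (0.69 log units; beyond the scatter), which is modest. Like the group in compound 1, the entering group has a five-membered aromatic ring and a six-membered aromatic ring of carbon only. For the measured compounds named here, the two groups are not identical, however, and no measured compound carries the new one, so only part of the large step is counted on.

In this assay, the expected change is a 6.2-fold lower number from compound 3 to compound 4 (0.79 log units; beyond the scatter). Compound 4 is estimated at 60 nM, with an expected range from 15 nM to 250 nM.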

Compound 4, half-maximal inhibitory concentration: 97 nM
Beside the measured number, compound 4's estimate is 1.6-fold (0.21 log units) below it, and the stated range covers the measured number.
By their numbers in this assay, from the lowest: compound 1; then compound 4; then compound 3; then compound 2.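

In this assay, 1-methyl-1H-indazol-6-yl shows that a group with a five-membered and a six-membered aromatic ring can outperform both single-ring groups at this position, with a 3.8-fold lower number from compound 3 to compound 4 (0.58 log units; beyond the scatter) and a 19-fold lower number from compound 2 to compound 4 (1.27 log units; beyond the scatter). Having both rings does not by itself match compound 1, however, as the change to the indazole gives a 5.1-fold higher number from compound 1 to compound 4 (0.71 log units; beyond the scatter). No measurement here explains this order of groups.

The indole and indazole groups differ both in ring nitrogen count and in attachment point, so the compounds shown leave open which difference matters. Going by these compounds, it also remains open how 1-methyl-1H-indazol-5-yl would compare with compound 1, and whether a phenyl ring bearing an amine or a carboxylic acid would be tolerated here.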